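The compounds below may be only part of what the source reports. "The series", "measured", "known", "first", "only" and "open" are said of these compounds alone.

Three compounds have been tested in a functional assay on MDA-MB-231 cells (Homo sapiens) for antiproliferative activity, read by MTT assay, with a stated time of 48 h; on this read-out lower numbers stand for stronger inhibition and higher numbers for weaker inhibition:

Compound 1 `C/C(=C\CC/C(C)=C/CC[C@@H]1[C@@]2(C)CCC(=O)C(C)(C)[C@H]2CC[C@@]1(C)O)CC/C=C(\C)C(=O)OCc1cn(-c2ccccc2Br)nn1`: > 150000 nM (a limit)
Compound 2 `C/C(=C\CC/C(C)=C/CC[C@@H]1[C@@]2(C)CCC(=O)C(C)(C)[C@H]2CC[C@@]1(C)O)CC/C=C(\C)C(=O)OCc1cn(-c2ccccc2C)nn1`: > 150000 nM (a limit)
Compound 3 `C/C(=C\CC/C(C)=C/CC[C@@H]1[C@@]2(C)CCC(=O)C(C)(C)[C@H]2CC[C@@]1(C)O)CC/C=C(\C)C(=O)OCc1cn(-c2ccccc2)nn1`: > 150000 nM (a limit)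

Compound 3 has no numerical value on this read-out. Its result is the limit > 150000 nM. The other two results are limits as well, so the series gives no ranking, and the evidence amounts to the limit of > 150000 nM in this assay, at which 3 of the 3 values shown sit.

Compound 4 `C/C(=C\CC/C(C)=C/CC[C@@H]1[C@@]2(C)CCC(=O)C(C)(C)[C@H]2CC[C@@]1(C)O)CC/C=C(\C)C(=O)OCc1cn(-c2cccc(F)c2)nn1` keeps the whole of compound 3 except for one change on the aryl group of the triazole: fluoro in place of hydrogen on an aromatic carbon. In words, this is fluoro in place of hydrogen on an aromatic carbon.

The closest measured changes also replace a group on an aromatic carbon. They are a step that the two limits leave unreadable from compound 1 to compound 3 and a step that the two limits leave unreadable from compound 2 to compound 3, and a step that the two limits leave unreadable from compound 1 to compound 2 belongs with them. None of these steps has a readable size, so they offer no direction for the new change. They show only that all three of these aryl variants ended at the limit.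

No step beyond the usual scatter is therefore expected in this assay, and a limit is the most likely outcome. The expected change is a number no higher from compound 3 to compound 4 (the limit leaves the size open). Compound 4 is estimated at 150000 nM. The expected range for compound 4 runs from 80000 nM to 300000 nM.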

Compound 4, half-maximal inhibitory concentration: 144000 nM
For compound 4 the middle estimate is 1.0-fold (0.02 log units) above the measured one; the measured number falls inside the stated range.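

In this assay, for the compounds shown here, compound 4, which carries 3-fluorophenyl on the triazole with fluoro meta to a large group, gives 144000 nM, the first actual number rather than a limit. The steps that can be read are an at least 1.0-fold lower number from compound 3 to compound 4 (0.01 log units; that floor lies within the scatter), an at least 1.0-fold lower number from compound 2 to compound 4 (0.01 log units; that floor lies within the scatter) and an at least 1.0-fold lower number from compound 1 to compound 4 (0.01 log units; that floor lies within the scatter); each of these is only a floor, so fluoro in place of hydrogen at this position is not shown to do anything beyond what repeated measurements would give, and the real size of each step remains unknown. The other three aryl variants remain at a single limit of the assay: the limit of > 150000 nM in this assay, at which 3 of the 4 values shown sit.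

From the compounds shown here alone, it remains open whether another group on this ring, such as methoxy, chloro or an amine, would give a number clearly lower than that of compound 4. The compounds shown also leave open how a change away from the aryl group, such as a carboxylic acid in place of the ester, would read in this assay.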